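Chloro to fluoro on the shared core

This account rests on a few compounds, and the source may have more. Where it says the series, first, only, none or still open, it means among the compounds named here.

In a physicochemical assay for lipophilicity, at pH 7.4 (a lower number here means a more polar compound, a higher number a more lipophilic compound), compound 2 `Cc1[nH]c2ccc(Cl)cc2c(=O)c1Br` gives 2.02 and stands highest of the two measured compounds. Compound 1 `Cc1ccc2[nH]c(C)c(Br)c(=O)c2c1` gives 1.07 in the same measurement. Compound 3 `Cc1[nH]c2ccc(F)cc2c(=O)c1Br` differs from compound 2 by fluoro in place of chloro on an aromatic carbon with fluoro in place of chloro on an aromatic carbon of a six-membered aromatic ring of carbon only.

Going by the values given here, only one measured step bears on this change. It is a number 0.95 log units higher from compound 1 to compound 2 (beyond the scatter) with chloro in place of methyl on an aromatic carbon. Chloro is involved again here, but no measured compound carries fluoro, so the guidance is partial. Leaving chloro is expected to lower the number, going by compound 1 and the step of a number 0.95 log units higher from compound 1 to compound 2 (beyond the scatter) as the only precedent, and a smaller size than that step is expected. The expected step is a number 0.52 log units lower from compound 2 to compound 3 (beyond the scatter) in this assay on this reading. For compound 3 the estimate is 1.5 with an expected range from 1.1 to 1.9 in this series.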

Compound 3, distribution coefficient: 1.61
Estimate against measurement, compound 3: 0.11 log units below, and the stated range covers the measured number.
By their numbers in this assay, from the lowest: compound 1; then compound 3; then compound 2.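

With fluoro on this aromatic carbon of the shared core, this assay now reads three groups at one place, and the new compound falls between the other two: there is a number 0.41 log units lower from compound 2 to compound 3 (beyond the scatter) on one side and a number 0.54 log units higher from compound 1 to compound 3 (beyond the scatter) on the other. Together with the earlier step from methyl to chloro, these steps separate the three groups in the order methyl, fluoro, chloro, from the lowest number to the highest, and none of the three compounds goes against that order. Going by these compounds alone, the choice of halogen at this carbon therefore shifts the number by itself, which the single step from methyl to chloro could not show.

From the compounds shown here alone, this order rests on three compounds with one core, and where a methoxy, a nitrile or an amine would fall at this carbon remains open. The data shown also give no explanation for the order of the three groups.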